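Methyl to Methoxy on a Breast Cancer Cell Screen

The compounds below may be only part of what the source reports. "The series", "measured", "known", "first", "only" and "open" are said of these compounds alone.

Of the compounds shown here, three have so far been tested in a functional assay on T47D cells (Homo sapiens) for cytotoxicity, with a stated time of 72 h, tested at 50 ug/mL; on this read-out lower numbers stand for a weaker effect and higher numbers for a stronger effect at the one concentration tested. Compound 1, with the structure `Cc1ccc(N2CCN/C2=N\N)cc1`, gives 17% in this assay. Compound 2, built on a different core, `O=c1[nH]nc2n(c1=O)CCN2c1ccc(Cl)cc1`, gives 1%, and compound 3, `Cc1ccc(N2CCn3c2n[nH]c(=O)c3=N)cc1`, gives 0%. Of these three numbers compound 1 stands highest; its gap to compound 2, the nearest of the other two, and its gap to compound 3, the furthest, both lie beyond the usual scatter of this kind of measurement, so compound 1 is the only one of the three with a clear effect at the single concentration tested.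

The next compound, compound 4, has the structure `COc1ccc(N2CCN/C2=N\N)cc1`. It keeps the whole core of compound 1 and differs in just one place: methoxy in place of methyl on an aromatic carbon. Going by the values given here, no pair of already measured compounds shows the effect of this particular change, so the expectation for compound 4 rests on compound 1 alone. Among the compounds with values here, with only one small group exchanged for another of similar size, no step beyond the scatter is expected from compound 1 to compound 4 in this assay, a number 2 percentage points lower from compound 1 to compound 4 (within the scatter). Compound 4 is therefore estimated to give about 15%, with a plausible range from 0% to 35%.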

Compound 4, a percentage reported as inhibition, at one concentration (the size of the read-out at that concentration, not a potency): 23%
Estimate against measurement, compound 4: 8 percentage points below; measured number inside the range.
By their numbers in this assay, from the lowest: compounds 3 and 2 (each within the scatter of the next); then compounds 1 and 4 (each within the scatter of the next).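

In this assay, methoxy in place of methyl on an aromatic carbon, para to a group of 7 heavy atoms, gives a number 6 percentage points higher from compound 1 to compound 4 (within the scatter). Going by these compounds alone, this is the first view of this position, since the earlier compounds offered no pair differing in one place; it shows that a swap bringing in an oxygen, counted as a hydrogen-bond acceptor, leaves the read-out for the core of compound 1 within the usual scatter, so at this single concentration the two groups cannot be told apart. Nothing measured here bears on why the two groups read alike.

The compounds shown leave open whether any group at this position would give a step beyond the scatter, for example an amine, a carboxylic acid, or a longer chain such as butoxy, since only methyl and methoxy can be compared here. They also leave open how the two compounds would compare at other concentrations, since a percentage at one concentration is the size of the effect there and not a potency.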